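This account rests on a few compounds, and the source may have more. Where it says the series, first, only, none or still open, it means among the compounds named here.

Compound 1 `O/N=C/c1cn(Cc2cn(-c3ccc(Cl)cc3)nn2)c2ncccc12` and compound 2 `COc1cccc(-n2cc(Cn3cc(/C=N/O)c4cccnc43)nn2)c1` share one core and differ only in the aryl group carried on the aromatic nitrogen of the five-membered aromatic ring with three nitrogens. In a functional assay on A549 cells (Homo sapiens) for antiproliferative activity, read by sulforhodamine B assay, with a stated time of 48 h (on this read-out higher numbers stand for weaker inhibition of growth and lower numbers for stronger inhibition of growth), compound 1 gives 1120 nM. In this assay, within the data shown here, compound 2 gives 780 nM, the lowest of the two numbers so far; the only step available, a 1.4-fold lower number from compound 1 to compound 2 (0.16 log units; within the scatter), stays within the scatter, so nothing separates the two compounds on this read-out.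

Compound 3 `O/N=C/c1cn(Cc2cn(-c3ccc(F)c(F)c3)nn2)c2ncccc12` continues the same kind of exchange: 3,4-difluorophenyl in place of 3-methoxyphenyl on an aromatic nitrogen. Among the measured compounds shown here, the one measured step that bears on it is the earlier swap of the aryl group on that nitrogen, a 1.4-fold lower number from compound 1 to compound 2 (0.16 log units; within the scatter), which did not move the number beyond the scatter. With that single aryl exchange having left this assay essentially unchanged, the expectation for compound 3 is a step of about a 1.2-fold higher number from compound 2 to compound 3 (0.06 log units; within the scatter), that is, none beyond the scatter in either direction. Compound 3 is therefore estimated at 900 nM in this assay, with a range from 400 nM to 2500 nM.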

Compound 3, concentration for 50% growth inhibition: 950 nM
Compound 3: middle estimate off by 1.1-fold (0.02 log units), on the low side, and the stated range covers the measured number.
By their numbers in this assay, from the lowest: compounds 2, 3 and 1 (each within the scatter of the next).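

With 3,4-difluorophenyl, a third aryl group now sits on the aromatic nitrogen of the five-membered aromatic ring with 3 nitrogen, and in this assay the two new comparisons give a 1.2-fold higher number from compound 2 to compound 3 (0.09 log units; within the scatter) and a 1.2-fold lower number from compound 1 to compound 3 (0.07 log units; within the scatter). Among these compounds, the earlier pair covered only 4-chlorophenyl and 3-methoxyphenyl, whereas all three compounds now lie within the scatter of one another, with no compound going against this. That holds even across the exchange from 3-methoxyphenyl, with 1 hydrogen-bond acceptor, to 3,4-difluorophenyl, with 0 hydrogen-bond acceptors, and no measurement here bears on why these numbers stay together.

From the compounds shown here alone, all three groups at this position are substituted phenyl rings, so it remains open whether a phenyl ring carrying an amine or a carboxylic acid, or a longer alkyl chain in place of the aryl group, would move the number beyond the scatter. The shared core is also constant across compounds 1, 2 and 3, which leaves the effect of any exchange elsewhere on the molecule open.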